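Compound 4: dimethylcarbamoyl in place of pyrrolidin-1-yl

The source may report more compounds than this note shows. Statements on the series, on what has been measured and on what is new or still open speak of the compounds shown alone.

In a toxicity assay on NIH3T3 cells (Mus musculus) for cytotoxicity, read by resazurin assay (on this read-out higher numbers stand for an effect only at larger amounts of compound and lower numbers for an effect already at smaller amounts), compound 3 (`c1ccc(-c2ccc(Cn3cncc3CNc3ccc(N4CCCC4)c(-c4ccccc4)c3)cc2)cc1`) gives > 1000 nM, which is a limit and not a number. Compound 1 (`CN(C)c1ccc(NCc2cncn2Cc2ccc(-c3ccccc3)cc2)cc1-c1ccccc1`) gives > 1000 nM, also a limit. Compound 2 (`CNC(=O)c1ccc(NCc2cncn2Cc2ccc(-c3ccccc3)cc2)cc1-c1ccccc1`) gives > 1000 nM, again a limit. Among the measured compounds shown here, the series so far offers only (the limit of > 1000 nM in this assay, at which 3 of the 3 values shown sit).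

Compound 4 (`CN(C)C(=O)c1ccc(NCc2cncn2Cc2ccc(-c3ccccc3)cc2)cc1-c1ccccc1`) differs from compound 3 in one place: dimethylcarbamoyl in place of pyrrolidin-1-yl on an aromatic carbon. In words, this is dimethylcarbamoyl in place of pyrrolidin-1-yl on an aromatic carbon.

For the measured compounds named here, three measured steps concern the same place: a step that the two limits leave unreadable from compound 1 to compound 2, a step that the two limits leave unreadable from compound 1 to compound 3 and a step that the two limits leave unreadable from compound 2 to compound 3. The last comes closest, since it also joins pyrrolidin-1-yl to a carbamoyl group, here methylcarbamoyl. None of the three gives a size or a direction. No readable step is therefore expected in this assay, in either direction, and another limit is the likeliest report. The expected step is a step that the limit leaves unreadable from compound 3 to compound 4. For compound 4 the estimated value is 2500 nM, with an expected range from 900 nM to 10000 nM.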

Compound 4, half-maximal effective concentration: > 1000 nM
Compound 4 gave a limit, no number; the forecaster's own chance of this, stated with the estimate: 85%; the middle value lies beyond the limit too.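

In this assay compound 4 gives > 1000 nM, which is a limit and not a number, and no step between compounds 1, 2, 3 and 4 can be read: the limit of > 1000 nM in this assay, at which 4 of the 4 values shown sit.

Open remains at what concentration any of these four compounds has an effect in this assay, and whether dimethylamino, methylcarbamoyl, pyrrolidin-1-yl or dimethylcarbamoyl on that aromatic carbon makes any difference.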